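From methyl to chloro on the shared core

The compounds below may be only part of what the source reports. "The series", "measured", "known", "first", "only" and "open" are said of these compounds alone.

Measured in a physicochemical assay for solubility; a lower number here means a less soluble compound, a higher number a more soluble compound:
- compound 1 `CNC(=O)c1sc(N2CC3CC2(CNC(=O)c2c[nH]c4ncc(C(F)(F)F)cc24)C3)nc1C(F)(F)F`: < 1600 nM
- compound 2 `CNC(=O)c1sc(N2CC3CC2(CNC(=O)c2c[nH]c4ncc(C)cc24)C3)nc1C(F)(F)F`: < 1600 nM

Compound 2 stands at a limit of this assay, < 1600 nM, and not at a number. Compound 1 likewise gives only a limit, < 1600 nM. The evidence so far comes down to the limit of < 1600 nM in this assay, at which 2 of the 2 values shown sit.

Compound 3 `CNC(=O)c1sc(N2CC3CC2(CNC(=O)c2c[nH]c4ncc(Cl)cc24)C3)nc1C(F)(F)F` carries chloro in place of methyl on an aromatic carbon. Within the data shown here, the one measured step bearing on this change is a step that the two limits leave unreadable from compound 1 to compound 2, with methyl in place of trifluoromethyl on an aromatic carbon, so it offers no size to carry over. No step beyond the scatter is therefore expected in this assay, and no direction can be given. The estimated change is a step that the limit leaves unreadable from compound 2 to compound 3. For compound 3 the estimated value is 1000 nM. The expected range for compound 3 runs from 400 nM to 1600 nM.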

Compound 3, solubility: 2000 nM
Compound 3: the middle estimate sits 2.0-fold (0.30 log units) below what was measured, and the stated range ends below it.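

In this assay, among these compounds, chloro gives the only number at this position that is not a limit, with an at least 1.2-fold higher number from compound 2 to compound 3 (0.09 log units; that floor lies within the scatter) for chloro in place of methyl and an at least 1.2-fold higher number from compound 1 to compound 3 (0.09 log units; that floor lies within the scatter) for chloro in place of trifluoromethyl. Both steps are floors within the scatter, so the position is shown to allow a measured number, but no real gain for chloro over either group is established, and the step between compound 1 and compound 2 cannot be read. The reading of this position still rests largely on a limit: the limit of < 1600 nM in this assay, at which 2 of the 3 values shown sit.

Going by these compounds, the actual values of compound 1 and compound 2 remain unknown, so the size of either step stays open. On these data alone, it is also open how this position responds to an amine, a carboxylic acid or a longer chain.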